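The source may report more compounds than this note shows. Statements on the series, on what has been measured and on what is new or still open speak of the compounds shown alone.

Working notes on the series, which shares one core and varies the aryl group on an aromatic nitrogen. The read-out is an ADME assay on MCF-10A cells (Homo sapiens) for cytotoxicity, read by MTT assay, with a stated time of 72 h; on this read-out lower numbers stand for stronger inhibition and higher numbers for weaker inhibition. In this assay, compound 1 (`COc1ccccc1-n1c(-c2coc3cc(C)c(Cl)cc3c2=O)nc(-c2ccccc2)c1-c1ccccc1`) stands at "not determined" (no result reported). Compound 2 (`Cc1cc2occ(-c3nc(-c4ccccc4)c(-c4ccccc4)n3-c3ccc(Cl)c(Cl)c3)c(=O)c2cc1Cl`) gives 98000 nM, the only numerical result so far. Compound 3 (`Cc1ccc(-n2c(-c3coc4cc(C)c(Cl)cc4c3=O)nc(-c3ccccc3)c2-c2ccccc2)c(C)c1`) stands at "not determined" (no result reported), so it has no position on the numerical scale and cannot serve as a quantitative starting point.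

The next step goes to compound 4 (`Cc1cc2occ(-c3nc(-c4ccccc4)c(-c4ccccc4)n3-c3ccc(Cl)cc3)c(=O)c2cc1Cl`), with 4-chlorophenyl in place of 2,4-dimethylphenyl on an aromatic nitrogen. Going by the values given here, no measured step between compounds is available, so the size of this change in this assay cannot be read from the series. With no number for compound 3, the expectation rests on compound 2 at 98000 nM. Compound 4 is expected to land within the scatter of that value, with no shift beyond it and no direction favoured. A single measured compound gives only a loose anchor, so the range is kept wide, and a report without a single number remains possible. For compound 4 the estimated value is 90000 nM, with an expected range of 30000 nM to 200000 nM.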

Compound 4, half-maximal inhibitory concentration: 92000 nM
The estimate for compound 4 lay 1.0-fold (0.01 log units) below the measured number; measured number inside the range.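

In this assay, going by these compounds alone, the step at the aryl group on the aromatic nitrogen, with hydrogen in place of chloro on an aromatic carbon, is a 1.1-fold lower number from compound 2 to compound 4 (0.03 log units; within the scatter) and so gives the first reading of a change at this position. With 4-chlorophenyl on that nitrogen, compound 4 stays within the scatter of compound 2, so within this pair the second chloro makes no discernible difference to the read-out. This pair covers one chloro exchange only, and steps involving compound 1 or compound 3 cannot be read, as neither carries a single number, so 2,4-dimethylphenyl cannot be placed against 4-chlorophenyl. No supporting measurement bears on this result, and the step stands without an explanation.

On these data alone, whether the same flat picture holds for very different substituents on this aryl group, such as an amine or a carboxylic acid, remains open. Also open, as far as these compounds go, is whether replacing the aryl group on the nitrogen with a longer alkyl chain would move the number in this assay beyond the scatter.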